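A methoxy-to-hydroxy change on a shared benzimidazole thioether core

A few compounds are considered here, and "the series" means these few. Any claim that something is new, unique, unknown or untested is made for them only; others in the source may bear on it.

Of the compounds shown here, two have been measured in a functional assay on HT-29 cells (Homo sapiens) for inhibition, read by flow cytometry, tested at 10 uM; a lower number here means less inhibition, a higher number more inhibition at the concentration tested (going by the name of the read-out). Compound 1 `CCOc1ccc(C(=O)CSc2nc3ccccc3[nH]2)cc1` gives 55.2% in this assay, and compound 2 `COc1ccc(C(=O)CSc2nc3ccccc3[nH]2)cc1OC` gives 52.6% in this assay. The value of compound 2 lies within the scatter of that of compound 1, so the two cannot be told apart on the numbers shown, and compound 2 stands neither ahead of nor behind compound 1.

The account now moves to compound 3 `COc1ccc(C(=O)CSc2nc3ccccc3[nH]2)cc1O`, which has not yet been measured in this assay. Compound 3 differs from compound 2 in one place: hydrogen in place of methyl on an oxygen on an aromatic ring. Within the data shown here, no step between measured compounds covers this kind of change, so there is nothing in the data to set its size or direction. With the two measured values sitting so close together, a small step is expected, and none beyond the scatter is claimed, in either direction.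

On that basis compound 3 is expected to give about 50% in this assay, within a range from 30% to 70%. The expected step from compound 2 to compound 3 is a number 2.6 percentage points lower from compound 2 to compound 3 (within the scatter).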

Compound 3, a percentage reported as inhibition, at one concentration (the size of the read-out at that concentration, not a potency): 49.7%
Beside the measured number, compound 3's estimate is 0.3 percentage points above it; the range from low to high includes it.
By their numbers in this assay, from the lowest: compounds 3, 2 and 1 (each within the scatter of the next).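

Among these compounds, the change from methoxy to hydroxy is the first single-place comparison in this account, and it comes to a number 2.9 percentage points lower from compound 2 to compound 3 (within the scatter) in this assay at the one concentration tested. On this oxygen on an aromatic ring, methyl and hydrogen therefore cannot be told apart on the numbers, so this position keeps its read-out with either group in this one pair. Nothing at hand explains that outcome, and this single pair sets no trend for the position.

What remains open is how far this position accepts other changes: the compounds shown do not tell how a longer chain on the oxygen, such as propoxy, would read, nor how an amine or a carboxylic acid in place of the hydroxy would. They also leave open whether the same hydrogen for methyl change would read alike on the other methoxy group of compound 3, and, with only a single-concentration percentage to go on, whether compound 2 and compound 3 would still match across a range of concentrations.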